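Shortening the chain: dimethoxypropyl gives way to butyl

This account rests on a few compounds, and the source may have more. Where it says the series, first, only, none or still open, it means among the compounds named here.

Measured compounds:
compound 1 `Nc1ccccc1NC(=O)/C=C/c1ccc(Cn2cnc3c(Nc4ccccc4)nc(Cl)nc32)cc1`: 28.7%
compound 2 `Nc1ccccc1NC(=O)c1ccc(Cn2cnc3c(Nc4cccc(OC(F)(F)F)c4)nc(Cl)nc32)cc1`: 62.4%
compound 3 `COC(CCn1cnc2c(NCc3ccc(C(=O)Nc4ccccc4N)cc3)nc(Cl)nc21)OC`: 51.2%

Of the compounds shown here, three sharing a core have been tested in a functional assay on NCI-H460 cells (Homo sapiens) for antiproliferative activity, read by CCK-8 assay, with a stated time of 72 h, tested at 8 uM; on this read-out lower numbers stand for a weaker effect and higher numbers for a stronger effect at the one concentration tested. Compound 3 stands second highest of the three; compound 2 is higher by a margin beyond the scatter, and compound 1 lies lower by a margin beyond the scatter. Compound 4 `CCCCn1cnc2c(NCc3ccc(C(=O)Nc4ccccc4N)cc3)nc(Cl)nc21` is the next compound: ethyl in place of dimethoxymethyl on a saturated chain carbon, two bonds along the chain from an aromatic nitrogen. Among the measured compounds shown here, no pair of measured compounds differs in one place only, so nothing measured here tells how large such a change can be. The step of a number 6.2 percentage points lower from compound 3 to compound 4 (within the scatter) is expected to be small, at most a modest decrease, perhaps none beyond the scatter. Compound 4 is thus expected to give 45%, within a range from 28% to 62%.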

Compound 4, a percentage reported as inhibition, at one concentration (the size of the read-out at that concentration, not a potency): 23.7%
For compound 4 the middle estimate is 21.3 percentage points above the measured one; the whole stated range lies above it.
By their numbers in this assay, from the lowest: compounds 4 and 1 (each within the scatter of the next); then compound 3; then compound 2.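

Among the compounds shown here, the change from 3,3-dimethoxypropyl to butyl is the first single-place comparison in this assay and gives a number 27.5 percentage points lower from compound 3 to compound 4 (beyond the scatter), so the read-out is sensitive to what sits at this chain position. Dimethoxymethyl, with its two hydrogen-bond acceptors, gives way here to ethyl, with none, and this one pair cannot show whether that difference is what matters. Nothing measured here says why the number falls. As far as these compounds go, whether the two methoxy groups matter singly or only together stays open. A 3-methoxypropyl chain, a 3-hydroxypropyl chain or a morpholine at the chain end would bear on that.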